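The source may hold more compounds than are shown below. What is called first, only, known or untested is meant among the compounds shown, and "the series" means these compounds.

Compound 1 `O=C(Nc1ccccc1)N1c2ccnn2CC1c1ccccc1` is the starting point. In a functional assay on cells (Neutrophil, Homo sapiens) for inhibition, with a stated time of 10 min (a lower number here means a stronger inhibitor, a higher number a weaker inhibitor), compound 1 gives > 1000 nM, which is a limit of the assay and not a number. Compound 2 `O=C(Nc1ccccc1F)N1c2ccnn2CC1c1ccccc1` gives in this assay > 1000 nM, again a limit. Compound 3 `O=C(Nc1ccc(F)cc1)N1c2ccnn2CC1c1ccccc1` gives in this assay > 1000 nM, also a limit. Because (the limit of > 1000 nM in this assay, at which 3 of the 3 values shown sit), none of the steps among these three can be read: the step that the two limits leave unreadable from compound 1 to compound 2, the step that the two limits leave unreadable from compound 1 to compound 3 and the step that the two limits leave unreadable from compound 2 to compound 3 all remain of unknown size. So far the series gives no number at all, only the shared limit.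

Compound 4 `O=C(NC1CC1)c1cnn2c1N(C(=O)Nc1ccccc1)C(c1ccccc1)C2` is the compound not yet measured. It differs from compound 1 by cyclopropylcarbamoyl in place of hydrogen on an aromatic carbon. Going by the values given here, none of the measured steps touches this part of the shared core; each of them concerns a fluoro in place of hydrogen or a 4-fluorophenyl in place of 2-fluorophenyl, and each is unreadable anyway. Among the compounds with values here, there is therefore no measured step from which a size or direction can be drawn for the change in compound 4. The expected step from compound 1 is a step that the limit leaves unreadable from compound 1 to compound 4, which is little more than a placeholder given that compound 1 itself stands at a limit. For compound 4 the estimate in this assay is 2000 nM, with a range from 300 nM to 10000 nM, and a limit rather than a number is the more probable outcome.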

Compound 4, half-maximal inhibitory concentration: 13.2 nM
For compound 4 the middle estimate is 150-fold (2.18 log units) above the measured one, outside the stated range (below it).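

In this assay, going by these compounds alone, cyclopropylcarbamoyl in place of hydrogen on the aromatic carbon of the five-membered aromatic ring with 2 nitrogen gives an at least 75-fold lower number from compound 1 to compound 4 (1.87 log units; beyond the scatter), the first step that can be read. Within the data shown here, the fluoro changes of the earlier compounds lay elsewhere and could not be read, so this result is the first to show that one change can bring the shared core from the limit to a measured value, and that this position tolerates a group much larger than hydrogen. The step can be stated only as a bound, because compound 1 has no number of its own: the limit of > 1000 nM in this assay, at which 3 of the 4 values shown sit.

The compounds shown do not separate the contribution of the amide from that of the three-membered ring, which a carboxylic acid, a nitrile, a primary amide or a longer chain on the amide nitrogen at the same carbon could help to resolve. Going by these compounds, it also remains open whether the fluoro changes of compound 2 and compound 3, unreadable at the limit, would have any measurable effect alongside cyclopropylcarbamoyl.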